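The compounds below may be only part of what the source reports. "The series", "measured", "known", "first", "only" and "open" are said of these compounds alone.

Compound 1, `CC(C)(C)c1ccc(Oc2ccc3c(NCCCNCc4ccco4)ccnc3c2)cc1`: 317 10^-6 cm/s
Compound 2, `COc1ccc(F)cc1CNCCCNc1ccnc2cc(C3CCCCC3)ccc12`: 23 10^-6 cm/s

Of the compounds shown here, two have so far been tested in an ADME assay for permeability, using PAMPA, with a stated time of 30 min, at pH 7.4; on this read-out lower numbers stand for lower permeability and higher numbers for higher permeability. Compound 1 gives 317 10^-6 cm/s, the higher of the two numbers, while compound 2 gives 23 10^-6 cm/s, a gap that lies beyond the usual scatter of repeated measurements of this kind. The next compound, compound 3 `COc1ccccc1Oc1ccc2c(NCCCNCc3ccco3)ccnc2c1`, has not yet been measured in this assay. It is built from compound 1 by one change: 2-methoxyphenyl in place of 4-(tert-butyl)phenyl on an oxygen on an aromatic ring. For the measured compounds named here, no pair of measured compounds differs by this single change, so the size of its effect is not known from the data at hand. With no direct comparison to rest on, the expectation is for a modest drop in this assay on going from compound 1 to compound 3, a step that may well stay within the scatter. Compound 3 is therefore expected to give 180 10^-6 cm/s, with a range from 70 10^-6 cm/s to 400 10^-6 cm/s. This amounts to an expected step of a 1.8-fold lower number from compound 1 to compound 3 (0.25 log units; within the scatter).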

Compound 3, apparent permeability: 317 10^-6 cm/s
Compound 3: the middle estimate sits 1.8-fold (0.25 log units) below what was measured, within the range that was stated.
By their numbers in this assay, from the lowest: compound 2; then compounds 1 and 3 (each within the scatter of the next).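

For the compounds shown here, putting 2-methoxyphenyl in place of 4-(tert-butyl)phenyl on an oxygen on an aromatic ring gives no change at the digits printed from compound 1 to compound 3 (within the scatter) in this assay, the first direct comparison at this position. The swap replaces a group of 10 heavy atoms, all carbon, with one of 8 heavy atoms that includes an oxygen and a hydrogen-bond acceptor, yet this read-out does not separate the two compounds. No measurement at hand offers a reason for this result.

This single pair cannot show whether the position would tolerate very different groups, such as an amine, a carboxylic acid or a longer chain. Going by these compounds alone, compound 2 differs from both other compounds in more than one place, so no step involving it can be read.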